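A few compounds are considered here, and "the series" means these few. Any claim that something is new, unique, unknown or untested is made for them only; others in the source may bear on it.

Compound 1 `COc1nc(N)nc2c1c(-c1ccsc1)cn2[C@@H]1O[C@H](CO)[C@@H](O)[C@H]1O`, in a functional assay on HeLa S3 cells (Homo sapiens) for antiproliferative activity, read by XTT assay, with a stated time of 72 h (a lower number here means a stronger inhibitor, a higher number a weaker inhibitor), compound 1 gives > 20000 nM.
Compound 2 `COc1nc(N)nc2c1c(-c1ccoc1)cn2[C@@H]1O[C@H](CO)[C@@H](O)[C@H]1O`, in this assay compound 2 gives > 20000 nM.
Compound 3 `CNc1ncnc2c1c(-c1ccsc1)cn2[C@@H]1O[C@H](CO)[C@@H](O)[C@H]1O`, in this assay compound 3 gives > 20000 nM.

Each of these three values is a limit of this assay, not a number. Compound 1 sits at the limit > 20000 nM, and so do compound 2 and compound 3; all three share (the limit of > 20000 nM in this assay, at which 3 of the 3 values shown sit). The change from compound 1 to compound 2 is furan-3-yl in place of thiophen-3-yl on an aromatic carbon, and the step that the two limits leave unreadable from compound 1 to compound 2 cannot be sized because both ends are limits.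

Compound 3 carries a different core from compound 1, and the difference between the two cores is not broken down here. Compound 4 `CNc1ncnc2c1c(-c1ccoc1)cn2[C@@H]1O[C@H](CO)[C@@H](O)[C@H]1O` has not yet been tested in this assay. It differs from compound 3 by furan-3-yl in place of thiophen-3-yl on an aromatic carbon, the same change already seen between compound 1 and compound 2, at the same place.

Since compound 1, compound 2 and compound 3 all sit at the limit, the step from compound 1 to compound 2 gives no readable size, and nothing shows that the change made either core active. Compound 4 is therefore expected to remain at the limit as well, with an expected step that the limit leaves unreadable from compound 3 to compound 4. The estimate for compound 4 in this assay is 30000 nM, expected between 15000 nM and 100000 nM.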

Compound 4, half-maximal inhibitory concentration: > 20000 nM
Compound 4: a limit, no number (the forecaster's own chance of this, stated with the estimate: 85%); the middle value is on the limit's open side.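

In this assay compound 4 gives > 20000 nM as a limit of the assay and not a number. No step can be read from compound 3 to compound 4, since both ends are limits: the limit of > 20000 nM in this assay, at which 4 of the 4 values shown sit. The compounds shown leave open how far each lies beyond that limit, and whether furan-3-yl and thiophen-3-yl differ at all in this assay on either core.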